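Butyl on the aromatic ring of compound 1

The source may report more compounds than this note shows. Statements on the series, on what has been measured and on what is new or still open speak of the compounds shown alone.

Measured in a functional assay on the whole organism for inhibition, with Rattus norvegicus as the target; a higher number here means that more compound is needed for the effect, a lower number that less compound is needed:
compound 1 `CC(C)c1ccc(OC(C)(Cc2ccccc2)C(=O)O)cc1` gives > 10 mg/kg (a limit)
compound 2 `Cc1cccc(CC(C)(Oc2ccc(C(C)C)cc2)C(=O)O)c1` gives < 1 mg/kg (a limit)
compound 3 `CCCCc1cccc(CC(C)(Oc2ccc(C(C)C)cc2)C(=O)O)c1` gives 1 mg/kg

In this assay compound 1 is known only as a limit, > 10 mg/kg. The other two compounds lie at lower numbers, and the value for compound 2 is also only a limit.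

The change under review is butyl in place of hydrogen on an aromatic carbon, which leads to compound 4 `CCCCc1ccc(CC(C)(Oc2ccc(C(C)C)cc2)C(=O)O)cc1`. It places butyl in place of hydrogen on an aromatic carbon, para to a large group.

The closest measured step is an at least 10-fold lower number from compound 1 to compound 3 (1.00 log units; beyond the scatter), the same exchange at a different ring carbon. Methyl gives a similar picture, an at least 10-fold lower number from compound 1 to compound 2 (1.00 log units; beyond the scatter). Both lie beyond the scatter, and both are bounds rather than exact sizes. The size of a number no lower from compound 2 to compound 3 (the limit leaves the size open) cannot be read.

For the measured compounds named here, no measured compound carries a group at the place it occupies in compound 4, so the transfer is uncertain. Resting on compound 3 at 1 mg/kg, a move to a lower number is expected, probably smaller than the measured steps suggest. The expected step is an at least 4.0-fold lower number from compound 1 to compound 4 (0.60 log units; beyond the scatter). The estimated value for compound 4 is 2.5 mg/kg, within an expected range of 0.5 mg/kg to 12 mg/kg.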

Compound 4, dose for half-maximal effect: 1 mg/kg
The estimate for compound 4 lay 2.5-fold (0.40 log units) above the measured number, and the stated range covers the measured number.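

In this assay, for the compounds shown here, butyl para to a large group gives an at least 10-fold lower number from compound 1 to compound 4 (1.00 log units; beyond the scatter), so this ring carbon, which carried no group in the earlier compounds, accepts butyl with a step beyond the scatter. Moving butyl to this carbon leaves the printed number unchanged: compound 3 gives 1 mg/kg and compound 4 gives 1 mg/kg, so these two compounds show no preference between the two ring carbons. The step remains a bound rather than an exact size because compound 1 is known only as a limit: the limit of > 10 mg/kg in this assay, at which 1 of the 4 values shown sits.

From the compounds shown here alone, whether methyl at this carbon would match butyl remains open, and steps resting on limits at both ends or on the limit for compound 2 cannot be read. Also open, going by these compounds, is how a longer chain, an amine or a carboxylic acid would behave at this carbon.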